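The compounds below may be only part of what the source reports. "The series", "measured", "known", "first", "only" and "open" are said of these compounds alone.

Measured compounds in a functional assay on KB cells (Homo sapiens) for antiproliferative activity, read by MTT assay, with a stated time of 72 h; a higher number here means a weaker inhibitor, a lower number a stronger inhibitor:

Compound 1 `COc1ccc(-c2ss/c(=N/O)c2-c2cc(OC)c(OC)c(OC)c2)cc1O` gives 850 nM.
Compound 2 `COc1ccc(-c2c(-c3cc(OC)c(OC)c(OC)c3)ss/c2=N/O)cc1[N+](=O)[O-]` gives 5260 nM.
Compound 3 `CO/N=c1/ssc(-c2ccc(OC)c(O)c2)c1-c1cc(OC)c(OC)c(OC)c1` gives 14500 nM.

Compound 1 and compound 2 share a core, but the difference between the two cores is not broken down here. Compound 3 arises from compound 1 by one change, (methyl in place of hydrogen on an oxygen), and this step in this assay is a 17-fold higher number from compound 1 to compound 3 (1.23 log units; beyond the scatter). Compound 4 `CO/N=c1/ssc(-c2cc(OC)c(OC)c(OC)c2)c1-c1ccc(OC)c([N+](=O)[O-])c1`, not yet measured, arises from compound 2 by the same change, (methyl in place of hydrogen on an oxygen), at the same place. Because a 17-fold higher number from compound 1 to compound 3 (1.23 log units; beyond the scatter) is large and beyond the scatter, a step of similar size is expected from compound 2 to compound 4, estimated as a 13-fold higher number from compound 2 to compound 4 (1.12 log units; beyond the scatter). Compound 4 is therefore expected to give about 70000 nM in this assay, with a likely range from 20000 nM to 250000 nM.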

Compound 4, half-maximal inhibitory concentration: > 100000 nM
Compound 4 ended at the assay's limit; the forecaster's own chance of this, stated with the estimate: 25%; middle value at least 1.4-fold (0.15 log units) from the limit.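

In this assay, the change from hydroxy to methoxy on the oxygen bonded to the double-bonded nitrogen gives an at least 19-fold higher number from compound 2 to compound 4 (1.27 log units; beyond the scatter), so the step goes the same way and is large on both cores: the same change on two cores in this assay, a 17-fold higher number (1.23 log units; beyond the scatter) from compound 1 to compound 3 and an at least 19-fold higher number (1.27 log units; beyond the scatter) from compound 2 to compound 4; the limit leaves it open whether they differ

For compound 4, > 100000 nM is a limit of the assay and not a number: the limit of > 100000 nM in this assay, at which 1 of the 4 values shown sits.

The series therefore does not show that the step has the same size on both cores, and two cores are too few to show that it holds across the series.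

The compounds shown leave open whether a longer chain on the same oxygen, such as ethyl, would give a similar step. They also leave open whether the change carries over to a core bearing an amine or a carboxylic acid.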